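A Smaller Ring Group in Place of the Benzoyl Amide

This account rests on a few compounds, and the source may have more. Where it says the series, first, only, none or still open, it means among the compounds named here.

Of the compounds shown here, three sharing one core have been measured in a physicochemical assay for solubility, read by LC-MS, in phosphate buffer, with a stated time of 24 h, at pH 7.4; a higher number here means a more soluble compound, a lower number a less soluble compound. Compound 1 `Fc1ccc2c(c1CNc1ncc(Oc3ccccc3)c3nncn13)CCO2`, which carries a phenoxy group, gives 8000 nM. Compound 2 `CC1(C)CC(=O)N(c2cnc(NCc3c(F)ccc4c3CCO4)n3cnnc23)C1`, with a 4,4-dimethyl-2-oxopyrrolidin-1-yl group in its place, gives 57000 nM. Compound 3 `CN(C(=O)c1ccccc1)c1cnc(NCc2c(F)ccc3c2CCO3)n2cnnc12`, with a benzoyl(methyl)amino group at the same position, gives 280000 nM, the highest of the three; both the step of a 4.9-fold higher number from compound 2 to compound 3 (0.69 log units; beyond the scatter) and the step of a 35-fold higher number from compound 1 to compound 3 (1.54 log units; beyond the scatter) lie beyond the scatter.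

Compound 4 `O=C1CC2(CC2)CN1c1cnc(NCc2c(F)ccc3c2CCO3)n2cnnc12` is the compound still to be measured. It differs from compound 3 in one place: a group of 8 heavy atoms (6 carbon, 1 nitrogen, 1 oxygen; one three-membered non-aromatic ring of carbon only, one five-membered non-aromatic ring with 1 hetero atom) in place of a group of 10 heavy atoms (8 carbon, 1 nitrogen, 1 oxygen; one six-membered aromatic ring of carbon only), on an aromatic carbon. The entering group, a five-membered non-aromatic ring with one hetero atom joined to a three-membered ring of carbon only, is closer in kind to the group of compound 2 than to the benzoyl(methyl)amino group of compound 3. The step of a 4.9-fold higher number from compound 2 to compound 3 (0.69 log units; beyond the scatter) therefore bears most directly on this change, and a step of comparable size in the opposite direction is expected. For compound 4 the expected step is a 4.7-fold lower number from compound 3 to compound 4 (0.67 log units; beyond the scatter). The estimate for compound 4 is 60000 nM, with a range from 20000 nM to 180000 nM.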

Compound 4, solubility: 130000 nM
The estimate for compound 4 lay 2.2-fold (0.34 log units) below the measured number, within the range that was stated.
By their numbers in this assay, from the lowest: compound 1; then compound 2; then compound 4; then compound 3.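

In this assay, the new result shows that a small change within one kind of group still registers at this position: the step of a 2.3-fold higher number from compound 2 to compound 4 (0.36 log units; beyond the scatter) comes with a three-membered ring of carbon only in place of the two methyl groups of the 4,4-dimethyl-2-oxopyrrolidin-1-yl group. The benzoyl(methyl)amino group keeps the highest number, with the step of a 2.2-fold lower number from compound 3 to compound 4 (0.33 log units; beyond the scatter) printed as beyond the scatter. The step of a 16-fold higher number from compound 1 to compound 4 (1.21 log units; beyond the scatter) makes this the third group here to give a higher number than phenoxy.

Going by these compounds, how an amine such as morpholine or a carboxylic acid would compare at this position remains open. Nothing measured here accounts for the differences between these groups.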